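Chain length at the amide-type nitrogen and half-life

The source may report more compounds than this note shows. Statements on the series, on what has been measured and on what is new or still open speak of the compounds shown alone.

Measured so far:
compound 1, `CCCCCCCNC(=O)Oc1ccc(Cl)cc1C(=O)Nc1cccc(Cl)c1`: 43 h
compound 2, `CCCCCCCCCNC(=O)Oc1ccc(Cl)cc1C(=O)Nc1cccc(Cl)c1`: 43 h
compound 3, `CCCNC(=O)Oc1ccc(Cl)cc1C(=O)Nc1ccc(Cl)cc1`: 43 h

In an ADME assay for metabolic stability, read by HPLC, at pH 7.4 (a higher number here means that the compound lasts longer, a lower number that the compound disappears faster), compound 1 gives 43 h. The step of no change at the digits printed from compound 1 to compound 2 (within the scatter) is the change (ethyl in place of hydrogen on a saturated chain carbon, seven bonds along the chain from an amide-type nitrogen). In this assay compound 2 gives 43 h, so lengthening the chain at that place leaves the half-life where it was.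

Compound 3 carries a different core from compound 1; the difference between the two cores is not broken down here. In this assay compound 3 gives 43 h, level with compounds 1 and 2 within the scatter, so the two cores read alike in this assay as far as these three compounds show.

Compound 4, `CCCCCNC(=O)Oc1ccc(Cl)cc1C(=O)Nc1ccc(Cl)cc1`, is not yet measured. It differs from compound 3 by ethyl in place of hydrogen on a saturated chain carbon, three bonds along the chain from an amide-type nitrogen. Among the compounds with values here, this is the same kind of change as the one from compound 1 to compound 2, but not the same: there the ethyl enters seven bonds along the chain from an amide-type nitrogen, here three bonds along the chain from an amide-type nitrogen. The nearest guide is still the step of no change at the digits printed from compound 1 to compound 2 (within the scatter), which was flat. The step of no change at the digits printed from compound 3 to compound 4 (within the scatter) is therefore expected to be no change beyond the scatter, resting on that flat step and on compound 3 giving 43 h. Compound 4 is estimated at 43 h, expected to fall between 22 h and 86 h.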

Compound 4, half-life: 43 h
Compound 4: the middle estimate sits on the measured number at the digits printed; the measured number falls inside the stated range.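

In this assay the new step reads no change at the digits printed from compound 3 to compound 4 (within the scatter), and set beside the earlier step on the other core the two agree: the same change on two cores in this assay, no change at the digits printed (within the scatter) from compound 1 to compound 2 and no change at the digits printed (within the scatter) from compound 3 to compound 4, 1.0-fold (0.00 log units) apart, within the scatter of two such steps

Ethyl in place of hydrogen on a saturated chain carbon therefore gives a flat step on both cores, and within these four compounds the core of compound 1 and the core of compound 3 give no sign of treating this change differently. Within the data shown here, this does not show that the change carries over in general: only two cores are compared, the ethyl enters at a different place on each (seven bonds along the chain from an amide-type nitrogen on one, three bonds on the other), and two flat steps show agreement only in the absence of a change, not that a step of real size would transfer from one core to the other.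

Still open, going by these compounds, is whether a chain carrying an amine or a carboxylic acid would read as the plain saturated chains do in this assay. Also open, on these data alone, is whether a branched chain, or a chain shorter than propyl such as methyl or ethyl, would stay level with these compounds on either core.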